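This account rests on a few compounds, and the source may have more. Where it says the series, first, only, none or still open, it means among the compounds named here.

Compound 1 `Cc1[nH]c2ccccc2c(=O)c1Cc1ccccc1` is the only one of the three measured compounds with a plain number: in a physicochemical assay for solubility, read by HPLC, at pH 7.4 (on this read-out lower numbers stand for lower solubility and higher numbers for higher solubility), compound 1 gives 10000 nM. Compound 2 `Cc1[nH]c2ccccc2c(=O)c1Br` reaches only a limit of this assay, > 20000 nM. Compound 3 `COc1ccc2[nH]c(C)c(Br)c(=O)c2c1` likewise sits at a limit, > 20000 nM. The two limits leave the step that the two limits leave unreadable from compound 2 to compound 3 unreadable, as the limit of > 20000 nM in this assay, at which 2 of the 3 values shown sit, shows. The difference between the cores of compound 1 and compound 2 is not broken down here. Compound 4 `COc1cccc2c(=O)c(Cc3ccccc3)c(C)[nH]c12` differs from compound 1 by methoxy in place of hydrogen on an aromatic carbon. This is the same kind of change as methoxy in place of hydrogen on an aromatic carbon, though the place differs: ortho and meta to a fused ring in compound 4, meta and para to a fused ring in compound 3. With the measured step unreadable, the expected step of a 1.3-fold lower number from compound 1 to compound 4 (0.10 log units; within the scatter) rests mainly on compound 1 at 10000 nM. Compound 4 is thus estimated at 8000 nM, between 3000 nM and 20000 nM.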

Compound 4, solubility: > 20000 nM
Compound 4: no number, only a limit; the forecaster's own chance of this, stated with the estimate: 15%; middle value at least 2.5-fold (0.39 log units) from the limit.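

In this assay, methoxy in place of hydrogen on an aromatic carbon gives an at least 2.0-fold higher number from compound 1 to compound 4 (0.30 log units; that floor lies within the scatter). Going by these compounds, compound 4 gives > 20000 nM, which is a limit and not a number, so the true size of the step stays unknown. The same kind of change on the core of compound 2 cannot be read and sits at a different place, so nothing here shows whether the step carries from one core to the other: the limit of > 20000 nM in this assay, at which 3 of the 4 values shown sit.

The compounds shown leave open what an amine or a carboxylic acid in place of the methoxy would give on the core of compound 1. They also leave open what a longer chain would give there.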